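The source may report more compounds than this note shows. Statements on the series, on what has been measured and on what is new or still open speak of the compounds shown alone.

Compound 1 (`COc1cc2c(Oc3ccc(NC(=O)Nc4ccccc4)cc3)ccnc2cc1OCCCCCCC(=O)NO`) gives 1650 nM in a functional assay on A549 cells (Homo sapiens) for antiproliferative activity, read by MTT assay; a lower number here means a stronger inhibitor, a higher number a weaker inhibitor. Compound 2 (`COc1cc2c(Oc3ccc(NC(=O)Nc4ccc(OC(F)(F)F)cc4)cc3)ccnc2cc1OCCCCCCC(=O)NO`) gives 3130 nM in this assay, which lies within the scatter of compound 1 at 1650 nM, so the two cannot be ranked. Compound 3 (`COc1cc2c(Oc3ccc(NC(=O)NC4CCCCC4)cc3)ccnc2cc1OCCCCCCC(=O)NO`) remains unmeasured. Its structural change from compound 2 is cyclohexyl in place of 4-(trifluoromethoxy)phenyl on an amide-type nitrogen.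

Going by the values given here, only one measured step bears on this change. That step, a 1.9-fold higher number from compound 1 to compound 2 (0.28 log units; within the scatter), replaces hydrogen with trifluoromethoxy on an aromatic carbon and stays within the scatter. It shows tolerance for a change on the aromatic ring, but only weakly, as the ring itself is kept in both compounds. Among the compounds with values here, no measured compound here carries a non-aromatic ring at this place, so the range has to stay wide. No shift beyond the scatter is expected, and no direction can be argued from these data. The expected step is a 1.3-fold lower number from compound 2 to compound 3 (0.10 log units; within the scatter). For compound 3 the estimated value is 2500 nM, with an expected range of 800 nM to 8000 nM.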

Compound 3, half-maximal inhibitory concentration: 850 nM
The estimate for compound 3 lay 2.9-fold (0.47 log units) above the measured number; the measured number falls inside the stated range.
By their numbers in this assay, from the lowest: compounds 3, 1 and 2 (each within the scatter of the next, the first and the last beyond it).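

In this assay, cyclohexyl on this amide-type nitrogen gives a 3.7-fold lower number from compound 2 to compound 3 (0.57 log units; beyond the scatter), the first step at this position beyond the scatter, so a non-aromatic ring is accepted here and an aromatic ring is not needed for activity at this level among these compounds. Against the unsubstituted ring, the same replacement gives a 1.9-fold lower number from compound 1 to compound 3 (0.29 log units; within the scatter), so compound 3 and compound 1 cannot be ranked, and the series shows no separate gain from cyclohexyl over phenyl. The step from compound 2 changes the ring and removes the trifluoromethoxy group together, and nothing available explains the difference in activity or assigns it to either change.

Open, from the compounds shown here alone, is whether a six-membered carbon ring is needed at all, which a cyclopropyl ring, an open n-butyl chain or a piperidine ring would test at the same nitrogen. Also open, going by these compounds, is whether the cyclohexyl ring accepts a substituent, such as a hydroxyl group or a carboxylic acid, and whether any such group would separate from compound 1 and compound 3 beyond the scatter.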